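This account rests on a few compounds, and the source may have more. Where it says the series, first, only, none or still open, it means among the compounds named here.

Compound 1 `COc1cc(Cl)cc(-c2nn(-c3cccc(NC(=O)Nc4cccc(C(F)(F)F)c4)c3)cc2-c2ccncc2)c1`: 11.2%; compound 2 `COc1cc(Cl)cc(-c2nn(-c3cccc(NC(=O)c4cccc(C(F)(F)F)c4)c3)cc2-c2ccncc2)c1`: 77%; compound 3 `COc1cc(Cl)cc(-c2nn(-c3cccc(NC(=O)Nc4ccc(Cl)c(Cl)c4)c3)cc2-c2ccncc2)c1`: 13.3%.

All three were tested in a functional assay on SW-620 cells (Homo sapiens) for inhibition, read by sulforhodamine B assay, with a stated time of 48 h, tested at 10 uM; a higher number here means a weaker effect of the compound at the concentration tested, a lower number a stronger effect. Compound 1 has the lowest number of the three, with compound 3 close by and compound 2 far off. The large step of a number 65.8 percentage points higher from compound 1 to compound 2 (beyond the scatter) followed a change at the carbonyl carbon, whereas the step of a number 2.1 percentage points higher from compound 1 to compound 3 (within the scatter), which swapped the group on the amide-type nitrogen, stayed within the scatter. Compound 4 `COc1cc(Cl)cc(-c2nn(-c3cccc(NC(=O)Nc4cc(C(F)(F)F)cc(C(F)(F)F)c4)c3)cc2-c2ccncc2)c1` differs from compound 1 by trifluoromethyl in place of hydrogen on an aromatic carbon. Since this again alters only the group on the amide-type nitrogen, no step beyond the scatter is expected. Compound 4 is therefore expected to give 14%, between 6% and 30%. The expected step is a number 2.8 percentage points higher from compound 1 to compound 4 (within the scatter).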

Compound 4, a percentage reported as activity, at one concentration (the size of the read-out at that concentration, not a potency): 7.18%
Compound 4: middle estimate off by 6.8 percentage points, on the high side; low and high end bracket the measured number.
By their numbers in this assay, from the lowest: compounds 4, 1 and 3 (each within the scatter of the next); then compound 2.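

In this assay, a second trifluoromethyl on the ring, meta to the first trifluoromethyl group, gives a number 4 percentage points lower from compound 1 to compound 4 (within the scatter), so adding these four heavy atoms at this position produces no step beyond the scatter. Compound 3 and compound 4 each differ from compound 1 on this same ring, and neither step leaves the scatter. No available evidence accounts for this tolerance.

Still open, on these data alone, is whether an amine, a carboxylic acid or a longer carbon chain at this position would also keep the read-out close to that of compound 1.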